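Replacing the large amine substituent with methyl

The source may report more compounds than this note shows. Statements on the series, on what has been measured and on what is new or still open speak of the compounds shown alone.

Measured so far in an ADME assay on THP-1 cells (Homo sapiens) for cytotoxicity, read by trypan blue exclusion, with a stated time of 48 h; on this read-out lower numbers stand for stronger inhibition of growth and higher numbers for weaker inhibition of growth:
compound 1 `Cc1c(CNCc2ccccc2)cc(-c2ccc(Cl)cc2)n1-c1ccc(Cl)cc1` gives 99 ug/mL
compound 2 `Cc1c(CN2CCN(C3CC4CCC3C4)CC2)cc(-c2ccc(Cl)cc2)n1-c1ccc(Cl)cc1` gives 429 ug/mL

Compound 2 holds the higher of the two numbers, and compound 1 lies lower by more than the scatter. Compound 3 `Cc1c(CN2CCN(C)CC2)cc(-c2ccc(Cl)cc2)n1-c1ccc(Cl)cc1` differs from compound 2 at one place (one carbon atom in place of a group of 7 heavy atoms (7 carbon; 2 five-membered non-aromatic rings of carbon only), on an amine nitrogen in a ring), with one carbon atom in place of a group of 7 heavy atoms, on an amine nitrogen in a ring. For the measured compounds named here, no measured pair shows this change, so the guide is weak. A modest move to a lower number, just beyond the scatter, is expected, with an estimated 2.3-fold lower number from compound 2 to compound 3 (0.35 log units; beyond the scatter). Compound 3 is expected at 190 ug/mL, within an estimated range from 70 ug/mL to 480 ug/mL.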

Compound 3, concentration for 50% growth inhibition: 3.23 ug/mL
For compound 3 the middle estimate is 59-fold (1.77 log units) above the measured one; measured number below the stated range.
By their numbers in this assay, from the lowest: compound 3; then compound 1; then compound 2.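

In this assay, a 130-fold lower number from compound 2 to compound 3 (2.12 log units; beyond the scatter) follows from methyl in place of the group of 7 heavy atoms on the amine nitrogen in the ring, so the read-out at this position is highly sensitive to the substituent. Against the benzylamino compound, a 31-fold lower number from compound 1 to compound 3 (1.49 log units; beyond the scatter) follows from 4-methylpiperazin-1-yl in place of benzylamino, leaving compound 3 with the lowest number of the three. Nothing available gives a cause for either step.

From the compounds shown here alone, whether the low number is specific to methyl remains open. Ethyl or hydroxyethyl on the same ring nitrogen would test how quickly the number rises with the group.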